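The source may report more compounds than this note shows. Statements on the series, on what has been measured and on what is new or still open speak of the compounds shown alone.

Within the data shown here, compound 2 `O=C(O)CC[C@@H](C(=O)O)N1C(=O)/C(=C/c2ccc(Br)cc2)SC1=S` gives the higher of the two numbers measured so far in an assay on isolated protein for displacement of a labelled ligand from Bcl-2-like protein 2 (Homo sapiens), read by fluorescence polarization; on this read-out lower numbers stand for stronger inhibition and higher numbers for weaker inhibition: compound 2 reads 610000 nM, whereas compound 1 `C[C@@H](C(=O)O)N1C(=O)/C(=C/c2ccc(Br)cc2)SC1=S` reads 243000 nM. Among the measured compounds shown here, the one step measured, a 2.5-fold higher number from compound 1 to compound 2 (0.40 log units; beyond the scatter), attaches the carboxymethyl that compound 3 now loses.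

Compound 3 `CC(C)C[C@@H](C(=O)O)N1C(=O)/C(=C/c2ccc(Br)cc2)SC1=S` differs from compound 2 by isopropyl in place of carboxymethyl on a saturated chain carbon, two bonds along the chain from an amide-type nitrogen in a ring and a carbonyl carbon. For the measured compounds named here, only the step from compound 1 to compound 2 bears on this change, and it covers just the departing group: removing the carboxymethyl should undo that modest step, while the entering isopropyl has no measured counterpart. The expected outcome is therefore a return toward the number of compound 1, stated with wide uncertainty.

For compound 3 the estimate in this assay is 250000 nM, with a range of 100000 nM to 650000 nM, which means an expected step of a 2.4-fold lower number from compound 2 to compound 3 (0.39 log units; beyond the scatter).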

Compound 3, inhibition constant: 31200 nM
Compound 3: the middle estimate sits 8.0-fold (0.90 log units) above what was measured; measured number below the stated range.
By their numbers in this assay, from the lowest: compound 3; then compound 1; then compound 2.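

At this saturated chain carbon, the outcome depends on which group enters. Isopropyl in place of hydrogen gives a 7.8-fold lower number from compound 1 to compound 3 (0.89 log units; beyond the scatter) in this assay, whereas carboxymethyl in place of hydrogen gave a 2.5-fold higher number from compound 1 to compound 2 (0.40 log units; beyond the scatter), so removing the carboxymethyl does not account for the whole change, and the swap of groups gives a 20-fold lower number from compound 2 to compound 3 (1.29 log units; beyond the scatter). No measurement here explains the opposite directions of these steps.

The three compounds do not separate the effect of branching from that of chain length, which an unbranched propyl or a longer alkyl chain would address. On these data alone, it also remains open whether a benzyl group would carry the trend further, or whether an amine at the end of the chain would behave like the carboxylic acid of compound 2.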